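This account rests on a few compounds, and the source may have more. Where it says the series, first, only, none or still open, it means among the compounds named here.

Three compounds have so far been measured in a functional assay on HeLa cells (Homo sapiens) for inhibition, read by MTT assay, with a stated time of 72 h; on this read-out lower numbers stand for stronger inhibition and higher numbers for weaker inhibition:

- compound 1 `O=[N+]([O-])c1cccc(Nc2nnc(-c3c[nH]c4ccccc34)o2)c1` gives 15100 nM
- compound 2 `O=[N+]([O-])c1ccc(Nc2nnc(-c3c[nH]c4ccccc34)o2)cc1` gives 1760 nM
- compound 3 `Clc1ccc(Nc2nnc(-c3c[nH]c4ccccc34)o2)cc1` gives 3800 nM

Compound 2 has the lowest number of the three, and compound 1 has the highest. The next compound to be tested is compound 4 `Fc1ccc(Nc2nnc(-c3c[nH]c4ccccc34)o2)cc1`, which has fluoro in place of nitro on an aromatic carbon, para to a large group, relative to compound 2 (fluoro in place of nitro on an aromatic carbon).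

Within the data shown here, one measured step bears on this change: a 2.2-fold higher number from compound 2 to compound 3 (0.33 log units; beyond the scatter), a modest rise with chloro in place of nitro on an aromatic carbon. Among the measured compounds shown here, no measured step yet shows fluoro itself, so this comparison is only a guide. With compound 3 at 3800 nM, a rise of similar modest size and the same direction is expected in this assay. The expected change is a 2.3-fold higher number from compound 2 to compound 4 (0.36 log units; beyond the scatter), with wide uncertainty. For compound 4 the estimated value is 4000 nM, with an expected range from 1500 nM to 11000 nM.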

Compound 4, half-maximal inhibitory concentration: > 100000 nM
Compound 4 ended at the assay's limit; the forecaster's own chance of this, stated with the estimate: 3%; at least 25-fold (1.39 log units) between middle value and limit.
By their numbers in this assay, from the lowest: compound 2; then compound 3; then compound 1. At a limit, above all of these: compound 4.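

In this assay compound 4 gives > 100000 nM, which is a limit of the assay and not a number. The earlier compounds shown here showed only a modest cost on replacing nitro at this aromatic carbon, para to a large group, whereas fluoro gives an at least 56-fold higher number from compound 2 to compound 4 (1.75 log units; beyond the scatter) and an at least 26-fold higher number from compound 3 to compound 4 (1.42 log units; beyond the scatter), so the choice of group here can decide between measurable inhibition and a value at the limit. Chloro keeps a measurable value and fluoro does not, so the two halogens are not interchangeable at this place in this series.

On these data alone, the true size of both steps stays unknown, since compound 4 has only a limit. As far as these compounds go, it also remains open how other groups at this carbon, such as an amine, a methoxy group or a carboxylic acid, would compare with nitro and chloro.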